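The source may report more compounds than this note shows. Statements on the series, on what has been measured and on what is new or still open speak of the compounds shown alone.

Measured compounds:
Compound 1, `CCCCNc1cc(Oc2c(OC)cc3cc(C#N)ccc3c2OC)nc(Nc2ccc(C#N)cc2)n1`. In an ADME assay on MT4 cells (Homo sapiens) for cytotoxicity, read by MTT assay, with a stated time of 5 days (on this read-out higher numbers stand for lower toxicity in this test and lower numbers for higher toxicity in this test), compound 1 gives only the assay's limit, > 125000 nM.
Compound 2, `CCC(C)Nc1cc(Oc2c(OC)cc3cc(C#N)ccc3c2OC)nc(Nc2ccc(C#N)cc2)n1`. In this assay compound 2 likewise gives only a limit, > 125000 nM.
Compound 3, `COc1cc2cc(C#N)ccc2c(OC)c1Oc1cc(NCC(C)(C)C)nc(Nc2ccc(C#N)cc2)n1`. In this assay compound 3 also gives only a limit, > 125000 nM.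

All three compounds share the same core and differ only in the group on the nitrogen on an aromatic ring. None of them reaches a measurable reading: each sits at the limit, so compound 3 cannot be placed above or below the other two. The steps between them are accordingly unreadable: a step that the two limits leave unreadable from compound 1 to compound 2, a step that the two limits leave unreadable from compound 1 to compound 3 and a step that the two limits leave unreadable from compound 2 to compound 3. For the measured compounds named here, the only evidence is the limit of > 125000 nM in this assay, at which 3 of the 3 values shown sit.

Compound 4, `COc1cc2cc(C#N)ccc2c(OC)c1Oc1cc(NCCC2=CCCCC2)nc(Nc2ccc(C#N)cc2)n1`, is the next compound in this series, not yet measured. It differs from compound 3 in one place: (cyclohex-1-en-1-yl)methyl in place of tert-butyl on a saturated chain carbon bound to a nitrogen on an aromatic ring.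

Going by the values given here, because of the limit of > 125000 nM in this assay, at which 3 of the 3 values shown sit, no measured step tells how a change at this position moves the reading, and there is no basis to expect a step beyond the scatter in this assay. The step from compound 3 to compound 4 is therefore expected to be a number no higher from compound 3 to compound 4 (the limit leaves the size open). Compound 4 is expected to give about 125000 nM, between 50000 nM and 300000 nM, and most probably only a limit again.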

Compound 4, half-maximal cytotoxic concentration: > 125000 nM
Compound 4 gave a limit, no number (the forecaster's own chance of this, stated with the estimate: 75%); the middle value sits exactly at the limit.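

Compound 4 also gives only a limit, so no step from compound 1, compound 2 or compound 3 to compound 4 can be read, and all four compounds stay unranked for one reason: (the limit of > 125000 nM in this assay, at which 4 of the 4 values shown sit). The compounds shown leave open whether changing the group on this nitrogen alters the cytotoxic concentration at all, and by how much.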